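The source may hold more compounds than are shown below. What is called first, only, known or untested is meant among the compounds shown, and "the series" means these compounds.

Measured so far:
compound 1, `Cc1c(Cn2ccnc2)c2cc(NS(=O)(=O)c3ccc(F)cc3)ccc2n1CCC(=O)O`, 3800 nM
compound 2, `O=C(O)CCn1cc(Cc2ccc(F)cc2)c2cc(NS(=O)(=O)c3ccc(F)cc3)ccc21`, 0.479 nM

In a functional assay on aorta for antagonist activity at thromboxane A2 receptor (Rattus norvegicus) (a higher number here means weaker binding, a lower number tighter binding), compound 2 holds the lowest of the two numbers; compound 1 lies far above it, well beyond the scatter. Compound 3, `Cc1ccc(S(=O)(=O)Nc2ccc3c(c2)c(Cc2ccc(F)cc2)cn3CCC(=O)O)cc1`, keeps the core of compound 2 and differs from it by methyl in place of fluoro on an aromatic carbon. Within the data shown here, no pair of measured compounds shows this change, so the size of the step is unknown from the data. The change is small, and the step of a 1.3-fold higher number from compound 2 to compound 3 (0.10 log units; within the scatter) is expected to stay within the scatter, with no clear direction. Compound 3 is therefore expected to come out at 0.6 nM, in the range 0.2 nM to 2 nM.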

Compound 3, dissociation constant: 0.269 nM
Compound 3: middle estimate off by 2.2-fold (0.35 log units), on the high side; the range from low to high includes it.
By their numbers in this assay, from the lowest: compounds 3 and 2 (each within the scatter of the next); then compound 1.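

In this assay, among these compounds, the step of a 1.8-fold lower number from compound 2 to compound 3 (0.25 log units; within the scatter) is the first reading of a change in one place, and it gives no order between 4-fluorophenyl and 4-methylphenyl on the sulfonyl. At this aromatic carbon, para to a large group, methyl in place of fluoro therefore keeps the number within the scatter. Nothing measured here bears on what lies behind this step.

Going by these compounds, whether an amine, a methoxy group or a carboxylic acid on this carbon would also stay within the scatter remains open. Compound 1 differs from compound 2 in more than one place, so its distance cannot be assigned to any single change.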